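The compounds below may be only part of what the source reports. "The series", "measured", "known", "first", "only" and "open" are said of these compounds alone.

Among the compounds with values here, compound 1 `CC(=O)OC(C)n1cnc2c(Cl)nc(I)nc21` is the one compound here with a measured number: in a functional assay on HEp-2 cells (Homo sapiens) for inhibition (a higher number here means a weaker inhibitor, a lower number a stronger inhibitor), compound 1 gives 6310 nM. Compound 2 `COc1nc(I)nc2c1ncn2OCCO` is a different case; for compound 2 the value > 500000 nM is a limit of the assay and not a number. The remaining value shown is therefore (the limit of > 500000 nM in this assay, at which 1 of the 2 values shown sits). So compound 1 stands alone among the numbers in this assay. Compound 3 `CC(=O)OC(C)n1cnc2c(N)nc(I)nc21` has not yet been measured in this assay. It differs from compound 1 in one place: amino in place of chloro on an aromatic carbon. Within the data shown here, no step between two measured compounds shows what such a change does in this assay. The expected step from compound 1 to compound 3 is a 1.3-fold higher number from compound 1 to compound 3 (0.10 log units; within the scatter), near the usual scatter and without a firm direction. Compound 3 is thus estimated at 8000 nM in this assay, with a range from 1500 nM to 50000 nM.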

Compound 3, half-maximal inhibitory concentration: > 500000 nM
Compound 3 ended at the assay's limit (the forecaster's own chance of this, stated with the estimate: 15%); middle value at least 62-fold (1.79 log units) away from the limit.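

Within the data shown here, the step gives the first reading of this position. In this assay, amino in place of chloro, on the aromatic carbon next to the ring nitrogen, gives an at least 79-fold higher number from compound 1 to compound 3 (1.89 log units; beyond the scatter), so this one exchange of a single heavy atom takes the core of compound 1 out of the measurable range. The value for compound 3 is a limit of the assay and not a number, and it joins the only other such value shown: the limit of > 500000 nM in this assay, at which 2 of the 3 values shown sit.

With no number for compound 3, the full size of the step stays open, and nothing shown says what lies behind it. Also open, going by these compounds, is whether the loss belongs to amino alone or would follow equally with bromo, a methylamino group or a hydroxyl group on this carbon.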